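Sulfonamide ring swap on a shared chromene core

A few compounds are considered here, and "the series" means these few. Any claim that something is new, unique, unknown or untested is made for them only; others in the source may bear on it.

Measured compounds:
compound 1 `CCOC1Oc2ccc(CC)cc2C(=O)/C1=C\Nc1ccccc1S(N)(=O)=O`: 400 nM
compound 2 `CCOC1Oc2ccc(F)cc2C(=O)/C1=C/Nc1ccc(S(=O)(=O)Nc2nnc(C)s2)cc1`: 10 nM
compound 3 `CCOC1Oc2ccccc2C(=O)/C1=C/Nc1ccc(S(=O)(=O)Nc2nnc(C)s2)cc1`: 85 nM

Three compounds share one core and differ in their substituents. In an assay on isolated protein for inhibition of Intestinal-type alkaline phosphatase (Bos taurus), read by spectrophotometry, with stated times of 10 min and 30 min (a lower number here means a stronger inhibitor, a higher number a weaker inhibitor), compound 2 gives the lowest number, compound 1 the highest, and compound 3 stands second highest of the three, with an 8.5-fold higher number from compound 2 to compound 3 (0.93 log units; beyond the scatter). Compound 3 and compound 1 show values that differ beyond the scatter, with compound 3 the lower of the two.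

Compound 4 `CCOC1Oc2ccccc2C(=O)/C1=C/Nc1ccc(S(=O)(=O)Nc2cc(OC)nc(OC)n2)cc1` is not yet measured. It differs from compound 3 by 2,6-dimethoxypyrimidin-4-yl in place of 5-methyl-1,3,4-thiadiazol-2-yl on a sulfonamide nitrogen. No measured step touches this part of the molecule: the only step shown, an 8.5-fold higher number from compound 2 to compound 3 (0.93 log units; beyond the scatter), concerns a substituent on the core, not the group on the sulfonamide nitrogen. There is therefore no direct guide, and the step from compound 3 to compound 4 is expected to be small, most likely within the scatter, in either direction: a 1.2-fold higher number from compound 3 to compound 4 (0.07 log units; within the scatter). Compound 4 is thus estimated at 100 nM in this assay, within a range of 30 nM to 300 nM.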

Compound 4, inhibition constant: 7800 nM
For compound 4 the middle estimate is 78-fold (1.89 log units) below the measured one; measured number above the stated range.
By their numbers in this assay, from the lowest: compound 2; then compound 3; then compound 1; then compound 4.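

In this assay the step of a 92-fold higher number from compound 3 to compound 4 (1.96 log units; beyond the scatter) comes from nothing more than 2,6-dimethoxypyrimidin-4-yl in place of 5-methyl-1,3,4-thiadiazol-2-yl on a sulfonamide nitrogen, so this position is far from indifferent to what it carries. The earlier compounds shown here showed a change only on the core, whereas here the core stays the same and the group on the sulfonamide nitrogen alone moves the number. No measurement shown here accounts for this loss.

Going by these compounds, the change swaps the ring and adds the methoxy groups in one move, so it remains open which of the two carries the loss. Also open, on these data alone, is how a simple group on that nitrogen, such as an unsubstituted phenyl or a methyl, would compare with these two.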